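Moving the ring substituent: from fluoro to hydroxy

This account rests on a few compounds, and the source may have more. Where it says the series, first, only, none or still open, it means among the compounds named here.

Measured so far:
- compound 1, `C=C(C)[C@@H]1CC=C(C)/C(=N/NC(=O)Nc2nnc(-c3ccc([N+](=O)[O-])cc3)o2)C1`: 300 mg/kg
- compound 2, `C=C(C)[C@@H]1CC=C(C)/C(=N/NC(=O)Nc2nnc(-c3ccc(F)cc3)o2)C1`: 300 mg/kg

In a functional assay on the whole organism (strain Swiss albino) with Mus musculus as the target, with a stated time of 4 h (on this read-out lower numbers stand for an effect already at smaller amounts and higher numbers for an effect only at larger amounts of compound), compound 2 gives 300 mg/kg and stands level with compound 1, the step of no change at the digits printed from compound 1 to compound 2 (within the scatter) being within the scatter. Compound 3, `C=C(C)[C@@H]1CC=C(C)/C(=N/NC(=O)Nc2nnc(-c3ccccc3O)o2)C1`, differs from compound 2 by 2-hydroxyphenyl in place of 4-fluorophenyl on an aromatic carbon. For the measured compounds named here, the only measured step bears on it loosely, since it too changed the substituent on this phenyl ring and left this assay unchanged. No change beyond the scatter is therefore expected, no change at the digits printed from compound 2 to compound 3 (within the scatter). For compound 3 an estimated 300 mg/kg is expected, within 150 mg/kg to 600 mg/kg.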

Compound 3, minimum effective dose: 300 mg/kg
Compound 3: the middle estimate sits on the measured number at the digits printed; measured number inside the range.
By their numbers in this assay, from the lowest: compounds 1, 2 and 3 (each within the scatter of the next).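

With 2-hydroxyphenyl in place of 4-fluorophenyl, the step in this assay is no change at the digits printed from compound 2 to compound 3 (within the scatter), and against 4-nitrophenyl it is no change at the digits printed from compound 1 to compound 3 (within the scatter). So this position accepts not only the 4-substituted phenyl groups of the earlier compounds but also a 2-substituted one that carries a hydrogen-bond donor, with no shift in the dose. No measured evidence explains this flat result. From the compounds shown here alone, whether an amine or a carboxylic acid on this phenyl ring would move the dose stays open, as does the effect of replacing the phenyl ring with a longer alkyl chain.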